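The source may hold more compounds than are shown below. What is called first, only, known or untested is meant among the compounds shown, and "the series" means these compounds.

Compound 1 `COc1ccc(Cn2c(C(=O)O)c(CNCc3ccc(O)c(OC)c3)c3ccc(C(C)C)cc32)cc1`: 8380 nM
Compound 2 `COc1ccc(Cn2c(C(=O)O)c(CN(C)Cc3cccc(OC)c3)c3ccc(C)cc32)cc1`: 33000 nM

In a functional assay on Bel-7402 cells (Homo sapiens) for antiproliferative activity, read by MTT assay, with a stated time of 72 h (a higher number here means a weaker inhibitor, a lower number a stronger inhibitor), compound 2 has the higher number of the pair at 33000 nM, so it is the weaker inhibitor, and its gap to compound 1 lies beyond the scatter. Compound 3 `COc1ccc(Cn2c(C(=O)O)c(CNCc3cccc(O)c3)c3ccc(C)cc32)cc1` has (3-hydroxybenzyl)amino in place of (3-methoxybenzyl)(methyl)amino on a saturated chain carbon bound to an aromatic carbon. Within the data shown here, no measured pair shows this change alone, so the only guide is that compound 1 reaches 8380 nM. A moderate fall is expected in this assay, estimated as a 1.9-fold lower number from compound 2 to compound 3 (0.29 log units; within the scatter). For compound 3 the estimate is 17000 nM, with a range from 6000 nM to 45000 nM.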

Compound 3, half-maximal inhibitory concentration: 19800 nM
Compound 3: the middle estimate sits 1.2-fold (0.07 log units) below what was measured; low and high end bracket the measured number.
By their numbers in this assay, from the lowest: compound 1; then compounds 3 and 2 (each within the scatter of the next).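

Replacing (3-methoxybenzyl)(methyl)amino with (3-hydroxybenzyl)amino on this saturated chain carbon gives a 1.7-fold lower number from compound 2 to compound 3 (0.22 log units; within the scatter) in this assay, so this position accepts the change without a readable shift in the number. The step alters two features at once, the methyl on the nitrogen and the methoxy on the ring, and it cannot show what each contributes alone. Nothing available explains this outcome.

Each of those two features remains to be tested on its own. A 3-aminobenzyl group at the same place also remains an open question.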